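Methoxy to hydroxy on the shared core: compound 2 to compound 3

The source may hold more compounds than are shown below. What is called first, only, known or untested is meant among the compounds shown, and "the series" means these compounds.

Measured so far:
- compound 1, `Cc1cc(O)cc(-c2nn(CC#N)cc2-c2ccnc(-c3ccc(Oc4ccccc4)cc3)c2)c1`: 2140 nM
- compound 2, `COc1cc(C)cc(-c2nn(CC#N)cc2-c2ccnc(-c3ccc(N(C)C)cc3)c2)c1`: 420 nM

In a functional assay on 786-0 cells (Homo sapiens) for inhibition, read by sulforhodamine B assay, with a stated time of 48 h (a lower number here means a stronger inhibitor of growth, a higher number a weaker inhibitor of growth), compound 2 gives the lower of the two numbers; compound 1 sits beyond the scatter above it. The two measured compounds differ in two places, so their gap cannot be assigned to either change on its own.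

Compound 3, `Cc1cc(O)cc(-c2nn(CC#N)cc2-c2ccnc(-c3ccc(N(C)C)cc3)c2)c1`, keeps the dimethylaminophenyl end of compound 2 and changes only the other aryl group: hydrogen in place of methyl on an oxygen on an aromatic ring, that is methoxy to hydroxy, 3-methoxy-5-methylphenyl to 3-hydroxy-5-methylphenyl. Among the compounds with values here, no measured pair shows this change in isolation. Compound 1 carries the hydroxy group and is the weaker of the two measured compounds, but its other end differs as well, so this is only a weak hint.

Expectation for compound 3: a step of a 1.5-fold higher number from compound 2 to compound 3 (0.19 log units; within the scatter) toward a somewhat higher number, of a size that may not exceed the scatter. Compound 3 is expected to give about 650 nM in this assay, within 200 nM to 2100 nM.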

Compound 3, concentration for 50% growth inhibition: 3410 nM
For compound 3 the middle estimate is 5.2-fold (0.72 log units) below the measured one; the whole stated range lies below it.
By their numbers in this assay, from the lowest: compound 2; then compounds 1 and 3 (each within the scatter of the next).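

In this assay, the hydroxy-for-methoxy change can now be read on its own: with the dimethylamino end held fixed, hydrogen in place of methyl on the oxygen gives an 8.1-fold higher number from compound 2 to compound 3 (0.91 log units; beyond the scatter) and so costs growth inhibition beyond the scatter. This places the methoxy group of the 3-methoxy-5-methylphenyl ring among the features that matter for this read-out when the dimethylamino end is present. With the hydroxy group held fixed, dimethylamino in place of phenoxy on an aromatic carbon gives a 1.6-fold higher number from compound 1 to compound 3 (0.20 log units; within the scatter) and thus separates the two hydroxy compounds by no more than the usual spread of repeated measurements. Nothing available bears on the reason for the loss at the oxygen.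

Within the data shown here, still open is whether the methoxy advantage carries over when phenoxy replaces dimethylamino at the other end, as only one matched pair shows this change. Also open, on these data alone, is how an ethoxy group or an amino group in the same place would compare with the methoxy and hydroxy groups.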